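Cytotoxicity in the Nitro-Sulfone Amide Series: Piperidine Amide

The compounds below may be only part of what the source reports. "The series", "measured", "known", "first", "only" and "open" are said of these compounds alone.

Measured so far in an ADME assay on HepG2 cells (Homo sapiens) for cytotoxicity, read by CellTiter-Glo and ATP content, with a stated time of 72 h; on this read-out lower numbers stand for an effect already at smaller amounts and higher numbers for an effect only at larger amounts of compound:
- compound 1 `CC1CCN(C(=O)CN(C)C(=O)c2ccc(S(C)(=O)=O)c([N+](=O)[O-])c2)CC1`: compound 1 gives > 27000 nM, a limit of the assay.
- compound 2 `CS(=O)(=O)c1ccc(C(=O)NCC(=O)N(Cc2ccccc2)Cc2ccccc2)cc1[N+](=O)[O-]`: compound 2 gives 11900 nM.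
- compound 3 `CS(=O)(=O)c1ccc(C(=O)NCCCC(=O)N2Cc3ccccc3C2)cc1[N+](=O)[O-]`: compound 3 gives > 27000 nM, a limit of the assay.

Where compound 3 stands in this assay, only a limit is known, and it shares that limit with another member of the set, as told by the limit of > 27000 nM in this assay, at which 2 of the 3 values shown sit. Going by the values given here, compound 2 is the one member with a number rather than a limit.

Compound 4 `CS(=O)(=O)c1ccc(C(=O)NCCCC(=O)N2CCCCC2)cc1[N+](=O)[O-]` differs from compound 3 in one place: a group of 6 heavy atoms (5 carbon, 1 nitrogen; one six-membered non-aromatic ring with 1 hetero atom) in place of a group of 9 heavy atoms (8 carbon, 1 nitrogen; one five-membered non-aromatic ring with 1 hetero atom, one six-membered aromatic ring of carbon only), on a carbonyl carbon. The carbonyl bearing the change has a saturated chain carbon as its other neighbour.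

Among the compounds with values here, no step between two measured compounds is available to scale this change. Given that compound 3 sits at the limit of > 27000 nM in this assay, at which 2 of the 3 values shown sit, the expectation for compound 4 is no change beyond the scatter in this assay, most likely again a limit. The step from compound 3 to compound 4 is estimated as a step that the limit leaves unreadable from compound 3 to compound 4. Compound 4 is accordingly expected to give 30000 nM, with a range from 12000 nM to 80000 nM.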

Compound 4, half-maximal effective concentration: > 27000 nM
Compound 4 was reported as a limit (the forecaster's own chance of this, stated with the estimate: 70%); the middle value does not contradict the limit.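

Compound 3 and compound 4 both sit at a limit of this assay, and no step can be read between them: the limit of > 27000 nM in this assay, at which 3 of the 4 values shown sit.

The compounds shown leave open whether piperidin-1-yl on the carbonyl carbon differs at all from the group it replaces, with no number on either side.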